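The source may report more compounds than this note shows. Statements on the series, on what has been measured and on what is new or still open speak of the compounds shown alone.

Measured compounds in a functional assay on K562 cells (Homo sapiens) for cytotoxicity, read by CCK-8 assay, with a stated time of 72 h; a lower number here means a stronger inhibitor, a higher number a weaker inhibitor:
- compound 1, `COc1ccccc1/C=c1/[nH]c(=O)/c(=C\c2ccccc2OC)n(C)c1=O`: 2200 nM
- compound 2, `COc1ccccc1/C=c1/[nH]c(=O)/c(=C\c2cccc(Cl)c2Cl)[nH]c1=O`: "not active" (no number reported) (no number reported)
- compound 3, `C=CCn1c(=O)/c(=C\c2cccc(Cl)c2Cl)[nH]c(=O)/c1=C\c1ccccc1OC`: 900 nM

Compound 3 holds the lowest of the two numbers in this assay. Its nearest neighbour by value is compound 1, whose number sits higher by a margin beyond the usual scatter. Compound 2 is reported only as "not active" (no number reported) in this assay, so no number can be set against it; the two compounds that carry a substituent on the ring nitrogen are the two that return a number.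

Compound 4, `COc1ccccc1/C=c1\c(=O)[nH]/c(=C/c2cccc(Cl)c2Cl)c(=O)n1C`, has not yet been measured in this assay. It differs from compound 3 in one place: hydrogen in place of vinyl on a saturated chain carbon bound to an aromatic nitrogen; cut one bond further out, the change reads allyl to methyl. The pair of arylidene groups and the rest of the shared core stay as in compound 3.

Going by the values given here, no single-change step between measured compounds covers this substitution, so no size is fixed by the data. With compound 3 at 900 nM as the anchor, a modest move toward a weaker number is expected, not far beyond the scatter. The expected step is a 1.7-fold higher number from compound 3 to compound 4 (0.22 log units; within the scatter). For compound 4 the estimate in this assay is 1500 nM, with a range from 600 nM to 4000 nM.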

Compound 4, half-maximal inhibitory concentration: 110 nM
Beside the measured number, compound 4's estimate is 14-fold (1.13 log units) above it, and the stated range ends above it.
By their numbers in this assay, from the lowest: compound 4; then compound 3; then compound 1.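

Going by these compounds alone, the group on the ring nitrogen carries far more weight than the earlier compounds could show: in this assay, cutting allyl back to methyl, with both arylidene groups held, gives an 8.2-fold lower number from compound 3 to compound 4 (0.91 log units; beyond the scatter) and fixes a size for this change for the first time. With methyl held on that nitrogen, 2,3-dichlorophenyl in place of 2-methoxyphenyl on the double-bonded chain carbon gives the larger step (a 20-fold lower number from compound 1 to compound 4 (1.30 log units; beyond the scatter)), so the arylidene group also counts in this assay, and compound 4 now stands ahead of both compounds it can be read against. No measurement shown here accounts for either step.

Going by these compounds, only allyl and methyl on that nitrogen return a number alongside the 2,3-dichlorophenyl group, so it remains open whether the trend runs smoothly through ethyl or a longer chain, or what a chain ending in an amine or a carboxylic acid would do. Also open, on these data alone, is whether the arylidene step keeps its size with allyl in place of methyl on the nitrogen, and how far these steps hold outside this assay in other cell lines.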